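This account rests on a few compounds, and the source may have more. Where it says the series, first, only, none or still open, it means among the compounds named here.

Compound 1 `CCc1cc(Nc2nc(N[C@@H](C)c3ccc(C#N)cn3)nc3cccc(F)c23)n[nH]1`: 91 nM
Compound 2 `CCc1cc(Nc2nc(N[C@@H](C)c3ccc(F)cc3)nc3cc(Cl)ccc23)n[nH]1`: 440 nM

Of the two measured compounds, compound 1 has the lower number in an assay on isolated protein for inhibition of G protein-coupled receptor kinase 6 (Homo sapiens), read by scintillation counting, radiometric assay and 33P incorporation, with a stated time of 80 min, in the presence of a further agent that is not named here (on this read-out lower numbers stand for stronger inhibition and higher numbers for weaker inhibition), and the gap to compound 2, which in this assay gives 440 nM, lies beyond the usual scatter. Compound 3 `CCc1cc(Nc2nc(N[C@@H](C)c3ccc(F)cn3)nc3cccc(F)c23)n[nH]1` differs from compound 1 by fluoro in place of cyano on an aromatic carbon. Among the compounds with values here, no pair of measured compounds isolates this change, so the expectation rests on compound 1 alone. A modest weakening is expected, a step of about a 2.2-fold higher number from compound 1 to compound 3 (0.34 log units; beyond the scatter). For compound 3 an estimate of 200 nM is given, within a range from 70 nM to 600 nM.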

Compound 3, half-maximal inhibitory concentration: 29 nM
The estimate for compound 3 lay 6.9-fold (0.84 log units) above the measured number, and the stated range ends above it.
By their numbers in this assay, from the lowest: compound 3; then compound 1; then compound 2.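

At the carbon para to a large group on the six-membered aromatic ring with 1 nitrogen, the change from 5-cyanopyridin-2-yl to 5-fluoropyridin-2-yl gives, in this assay, a 3.1-fold lower number from compound 1 to compound 3 (0.50 log units; beyond the scatter). The nitrile is therefore not required here for a low number, and fluoro, with fewer heavy atoms, does better. Nothing available accounts for this step. Going by these compounds, whether chloro, methyl, methoxy or an amine at this carbon would go lower remains open. Also open, on these data alone, is whether the step would hold on a core other than that of compound 1.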